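A few compounds are considered here, and "the series" means these few. Any claim that something is new, unique, unknown or untested is made for them only; others in the source may bear on it.

Compound 2, drawn as `CC1=C(C(=O)NC(C)C)C(c2cccs2)NC(=O)N1`, gives 40% in an assay on membranes from HEK293 cells for displacement of a labelled ligand from adenosine receptor A2b (Homo sapiens), read by scintillation counting, with a stated time of 30 min, tested at 1 uM; a higher number here means more inhibition at the concentration tested (going by the name of the read-out), a lower number less inhibition. That is the higher of the two numbers measured, though only just: compound 1, drawn as `CC1=C(C(=O)OC(C)(C)C)C(c2cccs2)NC(=O)N1`, gives 38% in this assay, and the step of a number 2 percentage points higher from compound 1 to compound 2 (within the scatter) amounts to a change within the scatter of the measurement. Compound 3, drawn as `CC1=C(C(=O)SC(C)C)C(c2cccs2)NC(=O)N1`, has not yet been measured. It differs from compound 2 in one place: isopropylsulfanyl in place of isopropylamino on a carbonyl carbon. Among the measured compounds shown here, the only measured step that bears on this position is the one from compound 1 to compound 2, which swapped a tert-butoxy group for an isopropylamino group on the same carbonyl carbon and left the number essentially where it was. With a single step as guide, and that step flat, the expectation for compound 3 is a step of a number 2 percentage points lower from compound 2 to compound 3 (within the scatter), and the value of compound 3 in this assay is estimated at 38%, most likely between 20% and 55%.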

Compound 3, a percentage reported as inhibition, at one concentration (the size of the read-out at that concentration, not a potency): 1%
Compound 3: middle estimate off by 37 percentage points, on the high side; the whole stated range lies above it.
By their numbers in this assay, from the lowest: compound 3; then compounds 1 and 2 (each within the scatter of the next).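

The substituent on this carbonyl carbon does matter: in this assay the isopropylsulfanyl group gives a number 39 percentage points lower from compound 2 to compound 3 (beyond the scatter) and a number 37 percentage points lower from compound 1 to compound 3 (beyond the scatter), whereas the earlier swap of tert-butoxy for isopropylamino had shown no change beyond the scatter. The loss of the amide hydrogen does not track this drop on its own, since compound 1 also lacks that hydrogen yet stands within the scatter of compound 2; what sets compound 3 apart from both is sulfur, rather than oxygen or nitrogen, joined to the carbonyl. Nothing shown here explains why the number falls.

On these data alone, it remains open whether isopropoxy on the same carbonyl carbon would group with compound 3 or with the other two. As far as these compounds go, it is also open whether methylsulfanyl or another sulfur-linked chain would behave like isopropylsulfanyl.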